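A Cyclohexylsulfamoyl Analogue in the Rat Aorta Series

This account rests on a few compounds, and the source may have more. Where it says the series, first, only, none or still open, it means among the compounds named here.

Compound 1 `CC(C)(C)C(=O)c1ccc2c(c1)[C@@H](/N=C(\NC#N)Nc1ccc(Cl)cc1)[C@H](O)C(C)(C)O2` is the starting point. Among the compounds with values here, in a functional assay (aorta) with Rattus norvegicus as the target (a higher number here means a weaker inhibitor, a lower number a stronger inhibitor), compound 1 gives 5400 nM, the highest of the three numbers measured so far. Compound 2 `CC1(C)Oc2ccc(S(=O)(=O)Nc3ccccc3)cc2[C@@H](/N=C(\NC#N)Nc2ccc(Cl)cc2)[C@@H]1O` gives 3300 nM in this assay, and compound 3 `CC1(C)Oc2ccc(S(=O)(=O)N3CCCCC3)cc2[C@@H](/N=C(\NC#N)Nc2ccc(Cl)cc2)[C@@H]1O` gives 1900 nM. The step of a 1.6-fold lower number from compound 1 to compound 2 (0.21 log units; within the scatter) stays within the scatter, whereas the step of a 2.8-fold lower number from compound 1 to compound 3 (0.45 log units; beyond the scatter) goes beyond it; the step of a 1.7-fold lower number from compound 2 to compound 3 (0.24 log units; within the scatter) is again within the scatter.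

Compound 4 `CC1(C)Oc2ccc(S(=O)(=O)NC3CCCCC3)cc2[C@@H](/N=C(\NC#N)Nc2ccc(Cl)cc2)[C@@H]1O` has not yet been measured. It differs from compound 1 in that (cyclohexylsulfamoyl in place of (tert-butyl)carbonyl on an aromatic carbon). This change shares features with both earlier steps: like compound 2 it carries a sulfamoyl group, and like compound 3 it carries a six-membered non-aromatic ring of carbon only. Both of those steps lowered the number from compound 1, one within the scatter and one modestly beyond it, so a lowering of similar size is expected here. Compound 4 is therefore estimated to give 2300 nM in this assay, with a range of 1100 nM to 4800 nM. That estimate corresponds to an expected step of a 2.3-fold lower number from compound 1 to compound 4 (0.37 log units; beyond the scatter).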

Compound 4, half-maximal inhibitory concentration: 11700 nM
Compound 4: middle estimate off by 5.1-fold (0.71 log units), on the low side; the measured number lies above the stated range.
By their numbers in this assay, from the lowest: compounds 3, 2 and 1 (each within the scatter of the next, the first and the last beyond it); then compound 4.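

On this aromatic carbon, a sulfonyl group does not guarantee a number at or below that of compound 1 in this assay, since the cyclohexylsulfamoyl group lands beyond the scatter on the high side (a 2.2-fold higher number from compound 1 to compound 4 (0.34 log units; beyond the scatter)). The group on the sulfonyl sulfur matters: cyclohexylamino in place of piperidin-1-yl raises the number (a 6.2-fold higher number from compound 3 to compound 4 (0.79 log units; beyond the scatter)), and so does cyclohexyl in place of phenyl on the sulfonamide nitrogen (a 3.5-fold higher number from compound 2 to compound 4 (0.55 log units; beyond the scatter)). No measurement available here explains these rises.

The compounds shown leave open whether a cyclopentyl ring or an n-butyl chain on the sulfonamide nitrogen would give a number closer to that of compound 4 or that of compound 2. They also leave open how a morpholine on the sulfonyl sulfur would compare with the piperidin-1-yl group of compound 3.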